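Removing the trifluoromethyl from the amide aryl ring

The source may hold more compounds than are shown below. What is called first, only, known or untested is meant among the compounds shown, and "the series" means these compounds.

Three close relatives share one core and have been tested in a functional assay on the whole organism for inhibition, with Rattus norvegicus as the target, read by paw edema, with stated times of 30 min and 3 h, at a dose of 0.28 mmol/kg by the oral route; on this read-out higher numbers stand for more inhibition at the one dose given (going by the name of the read-out) and lower numbers for less inhibition. Compound 1 `COc1ccc(-n2nc(C(N)=O)nc2-c2cc(OC)c(OC)c(OC)c2)cc1` gives 72%. Compound 2 `COc1ccc(-n2nc(C(=O)Nc3ccc(C)cc3)nc2-c2cc(OC)c(OC)c(OC)c2)cc1` gives 60%, and compound 3 `COc1ccc(-n2nc(C(=O)Nc3ccc(C(F)(F)F)cc3)nc2-c2cc(OC)c(OC)c(OC)c2)cc1` gives 65%. Compound 3 stands second highest of the three, yet its distance to both neighbours is within the scatter: a number 5 percentage points higher from compound 2 to compound 3 (within the scatter), and compound 1 sits only a little higher.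

The next compound, compound 4 `COc1ccc(-n2nc(C(=O)Nc3ccccc3)nc2-c2cc(OC)c(OC)c(OC)c2)cc1`, differs from compound 3 in one place: hydrogen in place of trifluoromethyl on an aromatic carbon. Among the measured compounds shown here, two measured steps bear on this. The step of a number 5 percentage points higher from compound 2 to compound 3 (within the scatter) shows that swapping one group for another at that aromatic carbon barely moved the number. The steps of a number 12 percentage points lower from compound 1 to compound 2 (beyond the scatter) and a number 7 percentage points lower from compound 1 to compound 3 (within the scatter) show that attaching any of these aryl groups to the amide nitrogen lowered the number modestly, but compound 4 keeps the aryl amide, so that loss is already built in.

Taken together, no step beyond the scatter is expected: a number 3 percentage points lower from compound 3 to compound 4 (within the scatter). Compound 4 is therefore estimated at 62%, with a range from 50% to 74%.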

Compound 4, a percentage reported as inhibition, in the whole organism at one dose (the size of the read-out at that dose, not a potency): 54%
For compound 4 the middle estimate is 8 percentage points above the measured one; low and high end bracket the measured number.
By their numbers in this assay, from the lowest: compounds 4, 2, 3 and 1 (each within the scatter of the next, the first and the last beyond it).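

In this assay, among the compounds shown here, the aromatic carbon on the amide ring proves not to be indifferent: removing trifluoromethyl gives a number 11 percentage points lower from compound 3 to compound 4 (beyond the scatter) and is the only step at this carbon that passes the scatter, whereas a number 6 percentage points lower from compound 2 to compound 4 (within the scatter) leaves hydrogen and methyl unseparated. On the amide nitrogen, the plain phenyl group gives a number 18 percentage points lower from compound 1 to compound 4 (beyond the scatter) on this read-out, so phenyl, like 4-methylphenyl, stands clearly apart from the simple amide, while 4-(trifluoromethyl)phenyl does not. Nothing measured here explains why hydrogen and trifluoromethyl are separated at this carbon.

The compounds shown carry only hydrogen, methyl and trifluoromethyl at this carbon, so it remains open whether a methoxy group, a chlorine atom or an amine there would fall nearer to compound 3 or to compound 4. Going by these compounds, it is also open whether a small chain on the amide nitrogen, such as an ethyl group, would stay as close to compound 1 as the trifluoromethyl-bearing aryl group does, or would fall away as the phenyl group does.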